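Bromo for Fluoro on a Scaffold Without Measured Toxicity

The source may hold more compounds than are shown below. What is called first, only, known or untested is meant among the compounds shown, and "the series" means these compounds.

Compound 1 `COc1ccc(-c2cnc(NC(=O)c3ccccc3F)n2C)cc1` was examined in a toxicity assay on THP-1 cells (Homo sapiens) for inhibition; on this read-out lower numbers stand for higher toxicity in this test and higher numbers for lower toxicity in this test. In this assay compound 1 gives only a limit of the assay, > 100000 nM. Compound 2 `Cn1c(-c2ccccc2)cnc1NC(=O)c1ncc[nH]1` likewise reaches only a limit: in this assay compound 2 gives > 100000 nM. Both values sit at the limit of > 100000 nM in this assay, at which 2 of the 2 values shown sit, so compound 1 cannot be ordered against compound 2 on these numbers. Compound 3 `COc1ccc(-c2cnc(NC(=O)c3ccccc3Br)n2C)cc1` has not yet been measured. It differs from compound 1 in one place: bromo in place of fluoro on an aromatic carbon. No step between measured compounds is available, so the size of effect of this kind of change cannot be read from the numbers shown. The expected step is a number no higher from compound 1 to compound 3 (the limit leaves the size open), which amounts to none beyond the scatter. Compound 3 is expected most likely to be reported again only as a limit. The estimate for compound 3 is 100000 nM, with a range from 40000 nM to 300000 nM.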

Compound 3, half-maximal cytotoxic concentration: > 100000 nM
Compound 3: a limit, no number; the forecaster's own chance of this, stated with the estimate: 85%; the middle value sits exactly at the limit.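

Like compound 1, compound 3 yields only a limit of the assay in this assay: compound 3 gives > 100000 nM. Going by these compounds alone, no step from compound 1 to compound 3 can be read, as every value shown is a limit: the limit of > 100000 nM in this assay, at which 3 of the 3 values shown sit. The compounds shown leave open how 2-fluorophenyl and 2-bromophenyl compare on this read-out, and at what concentration, if any, compounds on this core become toxic.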